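The source may report more compounds than this note shows. Statements on the series, on what has been measured and on what is new or still open speak of the compounds shown alone.

Measured so far in an ADME assay on Huh-7 cells (Homo sapiens) for cytotoxicity; on this read-out lower numbers stand for higher toxicity in this test and higher numbers for lower toxicity in this test:
compound 1 `Cc1cccc(-c2nn(-c3ccc(F)cc3F)cc2CNCCN2CCN(C)CC2)c1`: > 20000 nM
compound 2 `CN1CCN(CCNCc2cn(-c3ccc(C(F)(F)F)cc3)nc2-c2ccc(C(F)(F)F)cc2)CC1`: 1500 nM
compound 3 `Cc1ccccc1-c1nn(-c2ccc(Br)cc2)cc1CNCCN1CCN(C)CC1`: 9600 nM

In this assay, for the measured compounds named here, the read-out of compound 1 is a limit of the assay, > 20000 nM, and not a number; compound 1 is the one compound sitting at the limit of > 20000 nM in this assay, at which 1 of the 3 values shown sits. Compound 3 gives 9600 nM in this assay. Compound 2 gives 1500 nM in this assay, a lower number than compound 3 by more than the usual scatter. No pair among these three differs in a single place, so no measured step is available.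

Compound 4 `CN1CCN(CCNCc2cn(-c3ccc(F)cc3F)nc2-c2ccccc2Cl)CC1` is not yet measured. It differs from compound 1 in one place: 2-chlorophenyl in place of 3-methylphenyl on an aromatic carbon. Going by the values given here, no measured step isolates this change, so its size is open. Compound 2 and compound 3, both carrying halogen-bearing or trifluoromethyl-bearing phenyl groups, give numbers rather than limits in this assay, which points toward a number for compound 4 somewhat under the limit seen for compound 1. Compound 4 is therefore expected to give 12000 nM in this assay, with a range from 5000 nM to 25000 nM. The expected step is an at least 1.6-fold lower number from compound 1 to compound 4 (0.22 log units; that floor lies within the scatter), a small move toward lower numbers, and a repeat of the limit remains possible.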

Compound 4, half-maximal cytotoxic concentration: > 20000 nM
Compound 4 ended at the assay's limit; the forecaster's own chance of this, stated with the estimate: 35%; middle value at least 1.6-fold (0.22 log units) from the limit.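

In this assay compound 4 gives > 20000 nM, a limit of the assay and not a number. Compound 1 sits at that same limit, so no step can be read between compound 1 and compound 4: the limit of > 20000 nM in this assay, at which 2 of the 4 values shown sit.

On these data alone, whether 2-chlorophenyl in place of 3-methylphenyl changes the read-out at all, and by how much, stays open.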